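A few compounds are considered here, and "the series" means these few. Any claim that something is new, unique, unknown or untested is made for them only; others in the source may bear on it.

Series notes. Going by the values given here, compound 1 `CC(C)S(=O)(=O)N(Cc1ccccc1-c1ccccc1)[C@H]1CCNC1` is the only member with a number in an assay on HEK293 cells for inhibition of sodium-dependent dopamine transporter (Homo sapiens); a lower number here means a stronger inhibitor, a higher number a weaker inhibitor: compound 1 gives 2700 nM. Compound 2 `CC(C)CC(=O)N(Cc1ccccc1-c1ccccc1)[C@H]1CCNC1` was run in this assay as well, but compound 2 gives only "not determined" (no result reported) there. Compound 3 `CCS(=O)(=O)N(Cc1ccccc1-c1ccccc1)[C@H]1CCN(C)C1` likewise gives "not determined" (no result reported) in this assay, so compound 3 stands without a number and nothing places it against compound 1. Compound 4 `CCS(=O)(=O)N(Cc1ccccc1-c1ccccc1)[C@H]1CCNC1` is to be measured in this assay. Its change from compound 3 is hydrogen in place of methyl on an amine nitrogen in a ring. Among the compounds with values here, no step between measured compounds is available to size this change, so its direction is open; a shift beyond the usual scatter either way, or none at all, remains possible. The nearest reference is compound 1, which carries the same ring nitrogen hydrogen and gives 2700 nM. Compound 4 is estimated at 3000 nM, with a range of 700 nM to 12000 nM.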

Compound 4, inhibition constant: 2760 nM
Estimate against measurement, compound 4: 1.1-fold (0.04 log units) above; the range from low to high includes it.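

In this assay, going by these compounds alone, the only readable step is a 1.0-fold higher number from compound 1 to compound 4 (0.01 log units; within the scatter): at the saturated chain carbon bound to a saturated chain carbon and a sulfonyl sulfur, hydrogen in place of methyl leaves the number within the scatter. The step from compound 3 to compound 4 cannot be read, as compound 3 has no number, so 1-methylpyrrolidin-3-yl to pyrrolidin-3-yl remains unsized.

As far as these compounds go, whether a longer chain or a phenyl group on the sulfonyl sulfur would hold this level remains open. No measurement at hand explains the flat step.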